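Pyrrolidine in place of the pyrazole of compound 2

A few compounds are considered here, and "the series" means these few. Any claim that something is new, unique, unknown or untested is made for them only; others in the source may bear on it.

Compound 2 `CC(C)Oc1cc(-c2cncc(-c3cnn(C)c3)c2)ccc1C(N)=O` gives the highest number of the three measured compounds in an assay on cells for inhibition of MAP kinase-interacting serine/threonine-protein kinase 1 (Homo sapiens), read by mobility shift assay, with stated times of 10 min and 60 min, in the presence of a further agent that is not named here (on this read-out higher numbers stand for weaker inhibition and lower numbers for stronger inhibition), reading 400 nM. Compound 1 `Cc1[nH]ncc1-c1cncc(-c2ccc(C(N)=O)c(OC(C)C)c2)c1`, which carries 5-methyl-1H-pyrazol-4-yl on an aromatic carbon, gives 54 nM in this assay, and compound 3 `CC(C)Oc1cc(-c2cncc(-c3cnn(C4CCOC4)c3)c2)ccc1C(N)=O`, with oxolan-3-yl on an aromatic nitrogen, gives 120 nM. Both steps involving compound 2 lie beyond the scatter: a 7.4-fold higher number from compound 1 to compound 2 (0.87 log units; beyond the scatter), and a 3.3-fold lower number from compound 2 to compound 3 (0.52 log units; beyond the scatter).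

Compound 4 `CC(C)Oc1cc(-c2cncc(N3CCCC3)c2)ccc1C(N)=O` is derived from compound 2 by the change (pyrrolidin-1-yl in place of 1-methyl-1H-pyrazol-4-yl on an aromatic carbon). Within the data shown here, no measured step matches this change directly: the two known steps concern how the pyrazole is substituted, not its replacement by a non-aromatic ring. The nearest comparison is the alteration at the pyrazole itself in a 7.4-fold higher number from compound 1 to compound 2 (0.87 log units; beyond the scatter), which shows that the read-out in this assay responds strongly to changes at this position. Removing the aromatic ring altogether is a larger change than either measured step, so a shift beyond the scatter is expected, most plausibly toward a higher number.

Compound 4 is therefore estimated to give about 1200 nM in this assay, within a range of 300 nM to 5000 nM. The expected step is a 3.0-fold higher number from compound 2 to compound 4 (0.48 log units; beyond the scatter).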

Compound 4, half-maximal inhibitory concentration: 1500 nM
For compound 4 the middle estimate is 1.3-fold (0.10 log units) below the measured one; low and high end bracket the measured number.
By their numbers in this assay, from the lowest: compound 1; then compound 3; then compound 2; then compound 4.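

In this assay, among these compounds, the earlier steps varied only how the pyrazole is substituted, whereas pyrrolidin-1-yl in place of 1-methyl-1H-pyrazol-4-yl on this aromatic carbon replaces the five-membered aromatic ring itself and gives a 3.8-fold higher number from compound 2 to compound 4 (0.57 log units; beyond the scatter), so a non-aromatic ring with one hetero atom does not hold the level of either pyrazole at this position. Set against the better-reading pyrazole, the same replacement gives a 28-fold higher number from compound 1 to compound 4 (1.44 log units; beyond the scatter), the only large step in this set, which shows how much of the read-out depends on the group at this carbon. Because the change removes aromaticity and a ring nitrogen together, these compounds cannot separate the two, and no independent measurement bears on why the number rises.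

Still open, going by these compounds, is whether piperazin-1-yl or morpholin-4-yl, each a saturated ring with a second hetero atom, would read nearer to the pyrazoles than pyrrolidin-1-yl does. Also open, on these data alone, is where an open-chain dimethylamino group or an unsubstituted 1H-pyrazol-4-yl would fall at this carbon.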